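Swapping the nitrile-bearing ring for a chloro-fluoro ring

The source may hold more compounds than are shown below. What is called first, only, known or untested is meant among the compounds shown, and "the series" means these compounds.

Three compounds share a sulfonyl-linked aryl group on a bicyclic core. Compound 1 `Cc1ccc2ncc(S(=O)(=O)c3ccc(F)c(Cl)c3)c(N3CCC(C)CC3)c2c1` gives 93% in an assay on isolated protein for displacement of a labelled ligand from metabotropic glutamate receptor 5 (Homo sapiens), with a stated time of 60 min, tested at 1 uM; on this read-out higher numbers stand for more inhibition at the one concentration tested (going by the name of the read-out) and lower numbers for less inhibition. Compound 2 `Cc1ccc2ncc(S(=O)(=O)c3ccc(C#N)cc3)c(N3CCC(C)CC3)c2c1` gives 55% in this assay. Compound 3 `CC1CCN(c2c(S(=O)(=O)c3ccc(C#N)cc3)cnc3c(F)cccc23)CC1` gives 86% in this assay.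

Compounds 2 and 1 differ in one place: 3-chloro-4-fluorophenyl in place of 4-cyanophenyl on a sulfonyl sulfur. That change gives a number 38 percentage points higher from compound 2 to compound 1 (beyond the scatter). Compound 3 stands close to compound 1 and well apart from compound 2, but its core differs from the core of compound 2 in a way that is not broken down here.

Compound 4 `CC1CCN(c2c(S(=O)(=O)c3ccc(F)c(Cl)c3)cnc3c(F)cccc23)CC1` has not yet been measured. It differs from compound 3 in this way: 3-chloro-4-fluorophenyl in place of 4-cyanophenyl on a sulfonyl sulfur. The place of the change is the same in both pairs, so this is the same change. An upward step is expected from compound 3 to compound 4 in this assay, about a number 9 percentage points higher from compound 3 to compound 4 (within the scatter), smaller than the earlier one because compound 3 already gives 86%, leaving little room. Compound 4 is therefore estimated at 95%, between 87% and 100%.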

Compound 4, a percentage reported as inhibition, at one concentration (the size of the read-out at that concentration, not a potency): 95%
For compound 4 middle estimate and measured number coincide at the digits printed; the range from low to high includes it.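

On the core of compound 3, putting 3-chloro-4-fluorophenyl in place of 4-cyanophenyl gives a number 9 percentage points higher from compound 3 to compound 4 (within the scatter) in this assay, which on this core alone is no clear gain. Set beside the earlier step, the size of this change does not carry over unaltered from one core to the other: the same change on two cores in this assay, a number 38 percentage points higher (beyond the scatter) from compound 2 to compound 1 and a number 9 percentage points higher (within the scatter) from compound 3 to compound 4, 29 percentage points apart, beyond the scatter of two such steps Neither step goes downward, but two cores are too few to support a rule for the series, and a percentage at one concentration is not a potency, so the gap between the steps does not give the shift in potency on either core.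

The compounds shown leave open how the two cores compare with other groups on the sulfonyl sulfur, such as a phenyl ring carrying an amine or a carboxylic acid, or a plain alkyl chain. They also leave open whether the gap between the two steps would hold at a lower test concentration.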